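Carbamate to carbonate at the sugar hydroxymethyl

The source may report more compounds than this note shows. Statements on the series, on what has been measured and on what is new or still open speak of the compounds shown alone.

Compound 1 `CCNC(=O)OC[C@H]1O[C@@H](n2cnc3c(N)ncnc32)[C@H](O)[C@@H]1O` is the carbamate of the series. In an assay on COS-7 cells for inhibition of sodium/nucleoside cotransporter 2 (Homo sapiens), read by scintillation counting, in the presence of a further agent that is not named here (on this read-out lower numbers stand for stronger inhibition and higher numbers for weaker inhibition), compound 1 gives only a limit, > 100000 nM, so its true value is not known; on this read-out it sits at the limit as the limit of > 100000 nM in this assay, at which 1 of the 3 values shown sits, shows. The two measured analogues carry their substituent elsewhere on the shared core: compound 2 `Nc1ncnc2c1nc(NCc1cccc(Cl)c1)n2[C@@H]1O[C@H](CO)[C@@H](O)[C@H]1O` gives 5400 nM in this assay, and compound 3 `Nc1ncnc2c1nc(NCc1cccc(-c3ccccc3)c1)n2[C@@H]1O[C@H](CO)[C@@H](O)[C@H]1O` gives 21000 nM. Among the compounds with values here, the one comparable step, a 3.9-fold higher number from compound 2 to compound 3 (0.59 log units; beyond the scatter), brings in a phenyl ring and makes the number larger.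

Compound 4 `Nc1ncnc2c1ncn2[C@@H]1O[C@H](COC(=O)OCc2ccccc2)[C@@H](O)[C@H]1O` differs from compound 1 by benzyloxy in place of ethylamino on a carbonyl carbon. Within the data shown here, no measured step touches the carbonyl carbon itself; the only guide is that adding an aromatic ring in a 3.9-fold higher number from compound 2 to compound 3 (0.59 log units; beyond the scatter) did not lower the number. A change beyond the scatter in either direction is therefore not expected, and since compound 1 already stands at a limit, compound 4 is expected to stay there. The estimated step from compound 1 to compound 4 is a step that the limit leaves unreadable from compound 1 to compound 4, giving an estimated value for compound 4 of 150000 nM, within 40000 nM to 600000 nM.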

Compound 4, half-maximal inhibitory concentration: > 100000 nM
Compound 4 was reported as a limit; the forecaster's own chance of this, stated with the estimate: 70%; the middle value is on the limit's open side.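

Compound 1 and compound 4 are both reported only as limits in this assay and the step between them cannot be read: the limit of > 100000 nM in this assay, at which 2 of the 4 values shown sit.

The compounds shown leave open whether benzyloxy and ethylamino on this carbonyl carbon differ at all in this assay on this read-out.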